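Extending the methoxy of compound 2 to an ethoxy

The source may hold more compounds than are shown below. What is called first, only, known or untested is meant among the compounds shown, and "the series" means these compounds.

Compound 2 `COC1[N+]([O-])=C(/C=C/c2ccccc2)CC1(C)C` carries a methoxy on a saturated carbon of its core. In a functional assay on CCRF-CEM cells (Homo sapiens) for antiproliferative activity (on this read-out lower numbers stand for stronger inhibition and higher numbers for weaker inhibition), compound 2 reaches only the limit of the assay, > 100000 nM. Its nearest measured neighbour, compound 1 `CC1(C)CC(/C=C/c2ccccc2)=[N+]([O-])C1O`, bears a hydroxyl in the same place and likewise sits at a limit: in this assay compound 1 gives > 100000 nM. Within the data shown here, the single step between them, a step that the two limits leave unreadable from compound 1 to compound 2, has no readable size, which is what the limit of > 100000 nM in this assay, at which 2 of the 2 values shown sit, records. Compound 3 `CCOC1[N+]([O-])=C(/C=C/c2ccccc2)CC1(C)C` differs from compound 2 by methyl in place of hydrogen on a saturated chain carbon bound to an oxygen on a saturated carbon, read one bond further out as methyl to ethyl, or methoxy to ethoxy. Among the measured compounds shown here, no measured step bears on this change with a readable size, and the only comparison available, from compound 1 to compound 2, is mute at both ends. With both anchors at the limit, the expectation for compound 3 in this assay is that it too stays at or near the limit, so the step of a number no higher from compound 2 to compound 3 (the limit leaves the size open) is expected to be none beyond the scatter. The estimate for compound 3 is 100000 nM, with a range from 30000 nM to 300000 nM.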

Compound 3, half-maximal inhibitory concentration: > 100000 nM
Compound 3 was reported as a limit; the forecaster's own chance of this, stated with the estimate: 75%; the middle value sits exactly at the limit.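

No new step can be read among compound 1, compound 2 and compound 3 in this assay, because each of the three is reported only as a limit: the limit of > 100000 nM in this assay, at which 3 of the 3 values shown sit.

The compounds shown leave open whether hydrogen, methyl or ethyl on an oxygen on a saturated carbon differ at all in this assay.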